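Swapping a phenyl for a hexyl group

The source may report more compounds than this note shows. Statements on the series, on what has been measured and on what is new or still open speak of the compounds shown alone.

Compound 1 `[O-][n+]1nc(NCOCc2ccc(Cl)cc2)[n+]([O-])c2ccccc21`, compound 2 `COCNc1n[n+]([O-])c2ccccc2[n+]1[O-]` and compound 3 `[O-][n+]1nc(NCOCc2ccccc2)[n+]([O-])c2ccccc21` share one core. In a functional assay on PC-3 cells (Homo sapiens) for cytotoxicity, read by MTT assay, with a stated time of 72 h (a lower number here means a stronger inhibitor, a higher number a weaker inhibitor), compound 1 gives 5100 nM and compound 2 gives 4270 nM. Compound 3 gives 11900 nM, the highest number of the three, which makes it the weakest inhibitor here.

The next compound is compound 4 `CCCCCCCOCNc1n[n+]([O-])c2ccccc2[n+]1[O-]`. It is reached by one change: hexyl in place of phenyl on a saturated chain carbon bound to an oxygen on a saturated carbon.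

For the measured compounds named here, two measured steps bear on this. Phenyl in place of hydrogen gave a 2.8-fold higher number from compound 2 to compound 3 (0.45 log units; beyond the scatter), and hydrogen in place of chloro gave a 2.3-fold higher number from compound 1 to compound 3 (0.37 log units; beyond the scatter). Both are modest, and both end at the high number of compound 3. Going by the values given here, no measured compound carries a hexyl group, so this evidence is only indirect.

A modest move towards a lower number is therefore expected, estimated as a 2.2-fold lower number from compound 3 to compound 4 (0.34 log units; beyond the scatter). Compound 4 is expected to give about 5500 nM, with an estimated range from 2000 nM to 15000 nM.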

Compound 4, half-maximal inhibitory concentration: 390 nM
The estimate for compound 4 lay 14-fold (1.15 log units) above the measured number; the whole stated range lies above it.
By their numbers in this assay, from the lowest: compound 4; then compounds 2 and 1 (each within the scatter of the next); then compound 3.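

At this place on the chain, the earlier changes moved the number only modestly, yet replacing a ring with an open chain of the same carbon count gives a 31-fold lower number from compound 3 to compound 4 (1.48 log units; beyond the scatter) and is a large step. Losing the phenyl ring is not enough to explain this, since compound 2 also has no ring at this place, while hexyl still gives an 11-fold lower number from compound 2 to compound 4 (1.04 log units; beyond the scatter) and, against the 4-chlorophenyl group, a 13-fold lower number from compound 1 to compound 4 (1.12 log units; beyond the scatter) as well. No measurement available here explains why the hexyl compound stands so far apart.

A single chain length cannot show whether butyl or octyl would give a lower or a higher number than hexyl. On these data alone, it also remains open whether a hexyl chain ending in an amine or a carboxylic acid would keep the low number of compound 4.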